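This account rests on a few compounds, and the source may have more. Where it says the series, first, only, none or still open, it means among the compounds named here.

Three ureas sharing one core were tested in a functional assay on HCC827 cells (Homo sapiens) for inhibition, read by MTT assay, with a stated time of 48 h, tested at 10 uM; on this read-out lower numbers stand for less inhibition and higher numbers for more inhibition at the one concentration tested (going by the name of the read-out). Compound 1 `COc1cc(Br)ccc1Nc1cc(NC(=O)Nc2c(Cl)cccc2Cl)ncn1` gives 42.7% in this assay; compound 2 `COc1ccc(Br)cc1Nc1cc(NC(=O)Nc2c(Cl)cccc2Cl)ncn1` gives 53% in this assay; and compound 3 `CCc1ccc(Nc2cc(NC(=O)Nc3c(Cl)cccc3Cl)ncn2)cc1` gives 58% in this assay. Compound 2 thus stands second highest of the three numbers: its step from compound 1, a number 10.3 percentage points higher from compound 1 to compound 2 (beyond the scatter), lies beyond the scatter, while the step of a number 5 percentage points higher from compound 2 to compound 3 (within the scatter) lies within it. The remaining step, a number 15.3 percentage points higher from compound 1 to compound 3 (beyond the scatter), is the largest of the set but still modest.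

Compound 4 `COc1ccc(OC)c(Nc2cc(NC(=O)Nc3c(Cl)cccc3Cl)ncn2)c1` has not yet been measured in this assay. It differs from compound 2 in one place: methoxy in place of bromo on an aromatic carbon. Within the data shown here, no measured step exchanges bromo for methoxy at that position, so the guides are indirect. Moving the bromo, in a number 10.3 percentage points higher from compound 1 to compound 2 (beyond the scatter), shifted the inhibition modestly, and replacing the whole aryl, in a number 5 percentage points higher from compound 2 to compound 3 (within the scatter), stayed within the scatter. Both point to a change on this ring altering the inhibition only modestly at most. The step is therefore expected to be a number 3 percentage points lower from compound 2 to compound 4 (within the scatter), no larger than the scatter. Compound 4 is estimated at 50% in this assay, with a range from 35% to 65%.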

Compound 4, a percentage reported as inhibition, at one concentration (the size of the read-out at that concentration, not a potency): 94.1%
The estimate for compound 4 lay 44.1 percentage points below the measured number, and the stated range ends below it.
By their numbers in this assay, from the lowest: compound 1; then compounds 2 and 3 (each within the scatter of the next); then compound 4.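

In this assay, among these compounds, methoxy in place of bromo on the aromatic carbon para to a methoxy group gave a number 41.1 percentage points higher from compound 2 to compound 4 (beyond the scatter), a large step where the earlier steps on this aryl group were modest or within the scatter. This position therefore responds strongly to the group it carries, which the earlier moves of the bromo and the exchange of the whole aryl group did not reveal. Nothing available explains why this single exchange, of one bromine atom for a group of one carbon and one oxygen with one hydrogen-bond acceptor, has so large an effect.

The compounds shown leave open whether the gain is specific to methoxy or would also appear with another group on this carbon, such as an ethoxy group, a hydroxy group or an amine. They also leave open whether it depends on the methoxy group para to this position, and whether a ring with hydrogen at that other carbon would keep the gain.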